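This account rests on a few compounds, and the source may have more. Where it says the series, first, only, none or still open, it means among the compounds named here.

Measured so far in a functional assay on KB cells (Homo sapiens) for cytotoxicity; on this read-out lower numbers stand for stronger inhibition and higher numbers for weaker inhibition
- compound 1 `CCCOC1=CC(=O)c2ccccc2C1=O` gives 49400 nM
- compound 2 `CS(=O)(=O)OC1=CC(=O)c2ccccc2C1=O` gives 7180 nM

Compound 2 holds the lower of these two numbers, so it is the stronger inhibitor of the pair. The next compound is compound 3 `O=C1C=C(Oc2cccs2)C(=O)c2ccccc21`, which carries thiophen-2-yl in place of methylsulfonyl on an oxygen on an unsaturated carbon. Among the compounds with values here, only one measured step bears on this change, and it is modest: a 6.9-fold lower number from compound 1 to compound 2 (0.84 log units; beyond the scatter). That step shows that exchanging the group on this oxygen can move the number in this assay beyond the scatter. Still, neither propyl nor methylsulfonyl contains a ring, so the data say nothing direct about thiophen-2-yl. Within the data shown here, no step clearly beyond the scatter is therefore expected, with a slight lean towards a higher number, since compound 2 at 7180 nM sits at the low end of the two values. The estimate means a 1.7-fold higher number from compound 2 to compound 3 (0.22 log units; within the scatter). For compound 3 the estimated value is 12000 nM, with an expected range from 3000 nM to 45000 nM.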

Compound 3, half-maximal inhibitory concentration: 41500 nM
Estimate against measurement, compound 3: 3.5-fold (0.54 log units) below; the measured number falls inside the stated range.
By their numbers in this assay, from the lowest: compound 2; then compounds 3 and 1 (each within the scatter of the next).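

In this assay the change from methylsulfonyl to thiophen-2-yl gives a 5.8-fold higher number from compound 2 to compound 3 (0.76 log units; beyond the scatter) and so takes the number back up, whereas putting thiophen-2-yl in place of propyl gives a 1.2-fold lower number from compound 1 to compound 3 (0.08 log units; within the scatter) and separates those two compounds by nothing that can be read. On this oxygen on an unsaturated carbon, then, an aromatic ring and an open propyl chain cannot be told apart, and among these three compounds only methylsulfonyl stands apart, with steps beyond the scatter to both others. No measurement at hand explains what sets methylsulfonyl apart from the other two groups.

The three groups shown leave open whether the lower number of compound 2 belongs to the sulfonyl unit as such, which a phenylsulfonyl or an acetyl group on the same oxygen could help to separate. From the compounds shown here alone, it also stays open whether a longer chain, a chain ending in an amine, or a plain phenyl ring would fall with propyl and thiophen-2-yl or with methylsulfonyl.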